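Replacing dimethylamino with methyl on compound 1

The source may hold more compounds than are shown below. What is called first, only, known or untested is meant among the compounds shown, and "the series" means these compounds.

For the measured compounds named here, in a functional assay on CCRF-CEM cells (Homo sapiens), read by MTT assay, with a stated time of 72 h (on this read-out higher numbers stand for weaker inhibition and lower numbers for stronger inhibition), compound 1 `CN(C)c1ncnc2c1c(-c1ccsc1)cn2[C@@H]1O[C@H](CO)[C@@H](O)[C@H]1O` gives 3480 nM, the higher of the two numbers measured so far, while compound 2 `C#Cc1cn([C@@H]2O[C@H](CO)[C@@H](O)[C@H]2O)c2ncnc(N(C)C)c12` gives 90 nM. The next compound, compound 3 `Cc1ncnc2c1c(-c1ccsc1)cn2[C@@H]1O[C@H](CO)[C@@H](O)[C@H]1O`, keeps the core of compound 1 but carries methyl in place of dimethylamino on an aromatic carbon. Going by the values given here, only one measured step is available, a 39-fold lower number from compound 1 to compound 2 (1.59 log units; beyond the scatter). Among the compounds with values here, it is large, but it lies in a different place on the molecule, so it shows only that a single change can move the number far from that of compound 1. Within the data shown here, no measurement yet tests a change at the dimethylamino group. A moderate move toward a lower number is therefore expected, though with little certainty about its direction, and the expected step is a 2.3-fold lower number from compound 1 to compound 3 (0.37 log units; beyond the scatter). Compound 3 is estimated at 1500 nM, within an expected range of 200 nM to 10000 nM.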

Compound 3, half-maximal inhibitory concentration: 11200 nM
Estimate against measurement, compound 3: 7.5-fold (0.87 log units) below; measured number outside the range, above it.
By their numbers in this assay, from the lowest: compound 2; then compound 1; then compound 3.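

In this assay, for the compounds shown here, this is the first reading of a change at the dimethylamino position, on the aromatic carbon next to the ring nitrogen: with thiophen-3-yl held in place, the result is a 3.2-fold higher number from compound 1 to compound 3 (0.51 log units; beyond the scatter) and points toward weaker inhibition. The earlier step, a 39-fold lower number from compound 1 to compound 2 (1.59 log units; beyond the scatter) in this series, lay at a different place on the molecule and said nothing about this one, whereas this step shows that the number also responds to the group carried here, although modestly. Nothing shown gives a measured reason for the shift.

On these data alone, it remains open whether a primary amine, methylamino or methoxy at this position would read closer to compound 1 or to compound 3. As far as these compounds go, it is also open whether methyl in place of dimethylamino would move the number in the same direction on compound 2, which carries ethynyl.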